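Adding a Nitro Group: Expected Cytotoxicity of Compound 3

The compounds below may be only part of what the source reports. "The series", "measured", "known", "first", "only" and "open" are said of these compounds alone.

Measured compounds:
compound 1, `Cc1ccc(S(=O)(=O)Cc2nc(Nc3ccccc3)c3ccccc3n2)cc1`: "nd(insoluble)" (no result reported)
compound 2, `Cc1ccc(S(=O)(=O)Cc2nc(Nc3cccc(C(F)(F)F)c3)c3ccccc3n2)cc1`: > 25000 nM

In an ADME assay on HepG2 cells (Homo sapiens) for cytotoxicity, read by MTT assay, with a stated time of 72 h (on this read-out lower numbers stand for stronger inhibition and higher numbers for weaker inhibition), compound 1 gave "nd(insoluble)" (no result reported), so no number exists for it. Compound 2 in this assay reached only > 25000 nM, which is a limit of the assay and not a number. For the measured compounds named here, compound 2 therefore sits at the limit of > 25000 nM in this assay, at which 1 of the 2 values shown sits, with no measured step to any other compound to set against it.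

Compound 3, `Cc1ccc(S(=O)(=O)Cc2nc(Nc3cccc(C(F)(F)F)c3)c3cc([N+](=O)[O-])ccc3n2)cc1`, differs from compound 2 in one place: nitro in place of hydrogen on an aromatic carbon. Going by the values given here, no step between measured compounds is known here, so the size of such a change in this assay cannot be read from this set. A step of no size beyond the scatter is expected, leaving compound 3 close to where compound 2 stands. Compound 3 is thus expected to give about 30000 nM, within a range from 8000 nM to 100000 nM. The step that the limit leaves unreadable from compound 2 to compound 3 is expected to be small, and a result reported only as a limit is the likelier outcome.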

Compound 3, half-maximal inhibitory concentration: > 100000 nM
Compound 3: only a limit was reported; the forecaster's own chance of this, stated with the estimate: 70%; middle value at least 3.3-fold (0.52 log units) from the limit.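

In this assay compound 2 gives > 25000 nM, which is a limit and not a number. Compound 3 gives > 100000 nM, also a limit. For the compounds shown here, no step from compound 2 to compound 3 can be read from these two limits. The compounds shown leave open whether nitro in place of hydrogen on an aromatic carbon changes the result in this assay at all.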